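The compounds below may be only part of what the source reports. "The series", "measured", "known", "first", "only" and "open" are said of these compounds alone.

Series notes. Compounds 1, 2 and 3 share one core and differ only in the group carried on the sulfonyl-bearing aromatic ring. In a functional assay on PC-3 cells (Homo sapiens) for inhibition (a lower number here means a stronger inhibitor, a higher number a weaker inhibitor), compound 1 `COc1cc2nc(N3CCN(S(=O)(=O)c4ccc(Cl)cc4)CC3)nc(N)c2cc1OC` gives 23000 nM, compound 2 `COc1cc2nc(N3CCN(S(=O)(=O)c4ccc(Br)cc4)CC3)nc(N)c2cc1OC` gives 20000 nM, and compound 3 `COc1cc2nc(N3CCN(S(=O)(=O)c4ccc(-c5ccc(C)cc5)cc4)CC3)nc(N)c2cc1OC` gives 3400 nM. The step of a 1.2-fold lower number from compound 1 to compound 2 (0.06 log units; within the scatter) stays within the scatter. The steps of a 6.8-fold lower number from compound 1 to compound 3 (0.83 log units; beyond the scatter) and a 5.9-fold lower number from compound 2 to compound 3 (0.77 log units; beyond the scatter) are both beyond it, so compound 3 stands with the lowest number of the three in this assay.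

Compound 4 `COc1cc2nc(N3CCN(S(=O)(=O)c4ccc(-c5ccc(S(C)(=O)=O)cc5)cc4)CC3)nc(N)c2cc1OC` takes the next step from compound 3: methylsulfonyl in place of methyl on an aromatic carbon. Among the compounds with values here, no measured step bears directly on this change; the steps from compound 1 and compound 2 to compound 3 concern the group on the sulfonyl-bearing ring itself, not a substituent out on the 4-methylphenyl group. Within the data shown here, those steps show only that a larger group at that position is compatible with the lower numbers. The expectation for compound 4 in this assay is therefore a step of a 1.2-fold higher number from compound 3 to compound 4 (0.07 log units; within the scatter), close to no change beyond the scatter, with wide uncertainty. Compound 4 is estimated at 4000 nM, with a range from 1500 nM to 12000 nM.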

Compound 4, half-maximal inhibitory concentration: 7200 nM
Compound 4: middle estimate off by 1.8-fold (0.26 log units), on the low side; measured number inside the range.
By their numbers in this assay, from the lowest: compound 3; then compound 4; then compounds 2 and 1 (each within the scatter of the next).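

In this assay the group at the far end of the 4-methylphenyl substituent proves to matter: methylsulfonyl in place of methyl gives a 2.1-fold higher number from compound 3 to compound 4 (0.33 log units; beyond the scatter), the first step read at this outer place. The added aryl group keeps its advantage over the single halogen atoms despite that change, with a 2.8-fold lower number from compound 2 to compound 4 (0.44 log units; beyond the scatter) and a 3.2-fold lower number from compound 1 to compound 4 (0.50 log units; beyond the scatter), while compound 3 retains the lowest number of the four. Nothing measured here explains the rise from methyl to methylsulfonyl.

Going by these compounds, two groups at this place give no trend, so it remains open whether an amine, a carboxylic acid or a longer alkyl chain there would track with methyl or with methylsulfonyl. Also open, on these data alone, is whether any group at this place would bring the number below that of compound 3.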